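From cycloheptyl to (oxolan-3-yl)methyl on an aromatic nitrogen

The compounds below may be only part of what the source reports. "The series", "measured", "known", "first", "only" and "open" are said of these compounds alone.

Compound 1 `CN1C(=S)[C@@H](NC(=O)c2nc(Cc3ccccc3)n(C3CCCC3)n2)COc2ccccc21`: > 100000 nM
Compound 2 `CN1C(=S)[C@@H](NC(=O)c2nc(Cc3ccccc3)n(C3CCCCCC3)n2)COc2ccccc21`: > 100000 nM

These two compounds share the same core and differ only in the ring group on an aromatic nitrogen. Compound 2 gives > 100000 nM in a toxicity assay on HT-29 cells (Homo sapiens) for cytotoxicity (on this read-out lower numbers stand for higher toxicity in this test and higher numbers for lower toxicity in this test), and this is a limit of the assay, not a number. Compound 1 gives > 100000 nM, which is also a limit. The picture so far is therefore (the limit of > 100000 nM in this assay, at which 2 of the 2 values shown sit).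

Compound 3 `CN1C(=S)[C@@H](NC(=O)c2nc(Cc3ccccc3)n(CC3CCOC3)n2)COc2ccccc21` keeps the core and the benzyl group but carries (oxolan-3-yl)methyl in place of cycloheptyl on the same nitrogen: (oxolan-3-yl)methyl in place of cycloheptyl on an aromatic nitrogen.

Within the data shown here, the only measured swap at this place is a step that the two limits leave unreadable from compound 1 to compound 2, so no size carries over to the new step. With no measured size to follow, no step beyond the usual scatter is expected in this assay, and no direction is favoured. Compound 3 is expected to reach the same limit as its two relatives.

The estimated change is a number no higher from compound 2 to compound 3 (the limit leaves the size open). For compound 3 the expected value is 100000 nM, with an estimated range from 50000 nM to 200000 nM.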

Compound 3, half-maximal cytotoxic concentration: > 100000 nM
Compound 3 ended at the assay's limit (the forecaster's own chance of this, stated with the estimate: 90%); the middle value sits exactly at the limit.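

Compound 3 gives > 100000 nM in this assay, which is a limit of the assay and not a number. Among these compounds, compound 1 and compound 2 stand at the same limit, so no step among compound 1, compound 2 and compound 3 can be read. How far the group on the aromatic nitrogen can change toxicity in this test remains open: the limit of > 100000 nM in this assay, at which 3 of the 3 values shown sit.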